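This account rests on a few compounds, and the source may have more. Where it says the series, first, only, none or still open, it means among the compounds named here.

In a functional assay on K562 cells (Homo sapiens) for antiproliferative activity, read by MTT assay, with a stated time of 72 h (a lower number here means a stronger inhibitor of growth, a higher number a weaker inhibitor of growth), compound 1 `Cc1ccc(-n2nnc(C(=O)Nc3ccc(SC#N)cc3)c2C)cc1C` gives 9200 nM and compound 2 `Cc1ccc(Cl)cc1-n1nnc(C(=O)Nc2ccc(SC#N)cc2)c1C` gives 5700 nM so the two stand within the scatter of each other. Compound 3 `Cc1ccc(Cl)c(-n2nnc(C(=O)Nc3ccc(SC#N)cc3)c2C)c1` differs from compound 2 by 2-chloro-5-methylphenyl in place of 5-chloro-2-methylphenyl on an aromatic nitrogen with 2-chloro-5-methylphenyl in place of 5-chloro-2-methylphenyl on an aromatic nitrogen. For the measured compounds named here, because a 1.6-fold lower number from compound 1 to compound 2 (0.21 log units; within the scatter) is the only measured step and also concerns this aryl group, no step beyond the scatter is expected in this assay in either direction. The estimated change is a 1.1-fold higher number from compound 2 to compound 3 (0.02 log units; within the scatter) at the middle of the range. Compound 3 is expected at 6000 nM within an estimated range from 2500 nM to 14000 nM.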

Compound 3, concentration for 50% growth inhibition: 6600 nM
The estimate for compound 3 lay 1.1-fold (0.04 log units) below the measured number; measured number inside the range.
By their numbers in this assay, from the lowest: compounds 2, 3 and 1 (each within the scatter of the next).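

In this assay, moving from 5-chloro-2-methylphenyl to 2-chloro-5-methylphenyl on the aromatic nitrogen, with the same atoms joined differently, gives a 1.2-fold higher number from compound 2 to compound 3 (0.06 log units; within the scatter), so this exchange of the chlorine and the methyl group does not separate the two compounds. The other new comparison, a 1.4-fold lower number from compound 1 to compound 3 (0.14 log units; within the scatter), also leaves the three aryl groups shown within the scatter of one another. No evidence is available to explain these results. On these data alone, whether an aryl group carrying an amine or a carboxylic acid would give a step beyond the scatter remains open.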